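The source may report more compounds than this note shows. Statements on the series, on what has been measured and on what is new or still open speak of the compounds shown alone.

Within the data shown here, in an in vitro ADME assay on microsomes from liver (Homo sapiens) for metabolic stability (on this read-out lower numbers stand for a shorter-lived compound and higher numbers for a longer-lived compound), compound 2 `O=C1COCCN1c1ccc(C2CC(c3ccc([N+](=O)[O-])o3)=NO2)cc1F` stands highest of the two numbers so far at 8.31 h, while compound 1 `O=C1COCCN1c1ccc(C2CC(c3ccc([N+](=O)[O-])o3)=NO2)cn1` gives 1.52 h, a gap beyond the usual scatter. Compound 3 `CN1CCN(c2ccc(C3CC(c4ccc([N+](=O)[O-])o4)=NO3)cc2F)C(=O)C1` keeps the shared core of compound 2 and changes one group: 4-methyl-2-oxopiperazin-1-yl in place of 3-oxomorpholin-4-yl on an aromatic carbon. Among the measured compounds shown here, no measured pair shows this swap, so any forecast is loose. A modest shortening of the half-life is expected in this assay, an estimated 2.4-fold lower number from compound 2 to compound 3 (0.38 log units; beyond the scatter). Compound 3 is expected at 3.5 h, within an estimated range of 1.2 h to 9 h.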

Compound 3, half-life: 4.81 h
Compound 3: middle estimate off by 1.4-fold (0.14 log units), on the low side; the range from low to high includes it.
By their numbers in this assay, from the lowest: compound 1; then compounds 3 and 2 (each within the scatter of the next).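

Swapping 3-oxomorpholin-4-yl for 4-methyl-2-oxopiperazin-1-yl on this aromatic carbon gives a 1.7-fold lower number from compound 2 to compound 3 (0.24 log units; within the scatter) in this assay. Among these compounds, the half-life at this position therefore tolerates this ring exchange, something the earlier compounds, which offered no measured swap here, could not show. Nothing measured here explains why the two groups read alike. From the compounds shown here alone, it remains open whether an open-chain amine or a carboxylic acid on this carbon would keep the half-life. Also open, going by these compounds, is whether the same swap would read alike on the core of compound 1.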